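A pyridin-4-yl swap on compound 1

This account rests on a few compounds, and the source may have more. Where it says the series, first, only, none or still open, it means among the compounds named here.

Within the data shown here, compound 1 `CS(=O)(=O)c1ccc(-c2cnc3[nH]cc(-c4nnc(-c5ccc(Cl)cc5)o4)c(=O)c3c2)cc1` is one of two compounds measured in a functional assay on HCT-116 cells (Homo sapiens) for inhibition, read by MTT assay, with a stated time of 24 h, tested at 2.5 uM (on this read-out higher numbers stand for more inhibition of growth at the one concentration tested and lower numbers for less inhibition of growth), where compound 1 gives 2.06%, the lower of the two numbers. Compound 2 `N#Cc1ccc(-c2cnc3[nH]cc(-c4nnc(-c5ccc(Cl)cc5)o4)c(=O)c3c2)cc1` gives 13.7%, a change a number 11.6 percentage points higher from compound 1 to compound 2 (beyond the scatter). Compound 3 `CS(=O)(=O)c1ccc(-c2cnc3[nH]cc(-c4nnc(-c5ccncc5)o4)c(=O)c3c2)cc1` differs from compound 1 at another place: pyridin-4-yl in place of 4-chlorophenyl on an aromatic carbon. Among the measured compounds shown here, no measured step covers this change, and the one step seen was modest. The account therefore expects for compound 3 a step of a number 5.9 percentage points higher from compound 1 to compound 3 (within the scatter), small and uncertain in direction. Compound 3 is estimated at 8%, between 0% and 25%.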

Compound 3, percent growth inhibition at one concentration: 2.64%
Compound 3: the middle estimate sits 5.4 percentage points above what was measured; low and high end bracket the measured number.
By their numbers in this assay, from the lowest: compounds 1 and 3 (each within the scatter of the next); then compound 2.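

Within this assay the swap of 4-chlorophenyl for pyridin-4-yl gives a number 0.6 percentage points higher from compound 1 to compound 3 (within the scatter) and so shows no readable difference at this place. The ring nitrogen that enters, counted as one hydrogen-bond acceptor, thus leaves the number where it was, whereas the earlier step beyond the scatter lay at the other end of the molecule. Nothing at hand explains this result. Still open, as far as these compounds go, is whether an amine or a carboxylic acid on this ring would move the number, and whether pyridin-4-yl would give the same result alongside cyano in place of methylsulfonyl.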